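Two Acids on a Shared Core, One Still Unmeasured

A few compounds are considered here, and "the series" means these few. Any claim that something is new, unique, unknown or untested is made for them only; others in the source may bear on it.

The compounds here share one core and are compared in a functional assay on the whole organism for inhibition, with Rattus norvegicus as the target, at a dose of 10 mg/kg by the oral route; a higher number here means more inhibition at the dose given (going by the name of the read-out), a lower number less inhibition. Compound 1, `COc1cccc([C@H]2O[C@H](CC(=O)N3CCC(CC(=O)O)CC3)C(=O)N(CC(C)(C)COC(=O)C(C)C)c3ccc(Cl)cc32)c1OC`, is the reference point: in this assay compound 1 gives 34%. Compound 2, `COc1cccc([C@H]2O[C@H](CC(=O)N(C)CC(=O)O)C(=O)N(CC(C)(C)CO)c3ccc(Cl)cc32)c1OC`, carries a shorter side chain ending in an acid, and in this assay compound 2 gives -1%, the lowest of the two numbers measured; the gap to compound 1 lies beyond the usual scatter, so compound 2 shows essentially no inhibition at this dose.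

Compound 3, `COc1cccc([C@H]2O[C@H](CC(=O)NC(CC(C)C)C(=O)O)C(=O)N(CC(C)(C)CO)c3ccc(Cl)cc32)c1OC`, is not yet measured. It differs from compound 2 in one place: (1-carboxy-3-methylbutyl)amino in place of (carboxymethyl)(methyl)amino on a carbonyl carbon. The side chain thus grows by a branched alkyl arm and gains an amide hydrogen, while the acid stays.

Going by the values given here, nothing measured so far shows what this change does on this core. The expectation for the step from compound 2 to compound 3 in this assay is a small rise, a number 11 percentage points higher from compound 2 to compound 3 (beyond the scatter), possibly no larger than the scatter. Compound 3 is therefore estimated at 10%, within a range from -10% to 35%.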

Compound 3, a percentage reported as inhibition, in the whole organism at one dose (the size of the read-out at that dose, not a potency): 14%
Compound 3: the middle estimate sits 4 percentage points below what was measured; low and high end bracket the measured number.
By their numbers in this assay, from the lowest: compound 2; then compound 3; then compound 1.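

In this assay, putting (1-carboxy-3-methylbutyl)amino in place of (carboxymethyl)(methyl)amino on a carbonyl carbon gives a number 15 percentage points higher from compound 2 to compound 3 (beyond the scatter), so this position responds to what is attached there, and the step is modest but real. Both groups end in a carboxylic acid and the rest of the molecule stays the same, so having an acid on this side chain does not by itself tie the compound to the near-zero reading of compound 2. Nothing available explains why the number moves, so the step describes an outcome and not a mechanism.

This single change does several things at once: it adds the branched alkyl arm, and it replaces the methyl on the amide nitrogen with the amide hydrogen, so the compounds shown cannot say which part matters. A (1-carboxy-3-methylbutyl)(methyl)amino group would keep the arm while restoring the methyl, and a (1-carboxyethyl)amino group would shorten the arm to a single methyl, so these two would begin to pull the effects apart.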